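The source may hold more compounds than are shown below. What is called first, only, known or untested is meant among the compounds shown, and "the series" means these compounds.

Compound 1 `CC(C)n1nc(-c2cc(-c3ccccc3)on2)c2c(N)ncnc21` in an ADME assay on BaF3 cells (Mus musculus) for cytotoxicity, read by MTT assay, with a stated time of 48 h (a lower number here means a stronger inhibitor of growth, a higher number a weaker inhibitor of growth), gives > 10000 nM, a limit of the assay rather than a number.
Compound 2 `CC(C)n1nc(/C=N/OCc2ccccc2)c2c(N)ncnc21` gives > 10000 nM, again only a limit.
Compound 3 `Nc1ncnc2c1c(-c1cc(C3CC3)on1)nn2C1CCOCC1` gives > 10000 nM, also a limit.

These three compounds share a core and differ in the group that hangs from it. None of them has a measured value in this assay: for each the readout stopped at the limit, so all that can be said is that none slows the growth of these cells within the tested range. Compound 2 therefore stands where the other two stand, at the limit, with no number to set it apart from them. The only pattern in what has been measured is the limit of > 10000 nM in this assay, at which 3 of the 3 values shown sit.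

Compound 4 `CC(C)n1nc(/C=N/O)c2c(N)ncnc21` has not been measured yet. It comes from compound 2 by one change: hydrogen in place of benzyl on an oxygen. Among the measured compounds there is no pair differing in a single place, so no step of known size can guide what this change might do. Given that compound 2 sits at the limit with > 10000 nM, the expectation is that the step that the limit leaves unreadable from compound 2 to compound 4 stays within the usual scatter and leads to no measurable growth inhibition. The estimate for compound 4 in this assay is 20000 nM, with a range from 8000 nM to 60000 nM, and most likely the assay would once more report only a limit.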

Compound 4, concentration for 50% growth inhibition: > 10000 nM
Compound 4 was reported as a limit; the forecaster's own chance of this, stated with the estimate: 85%; the middle value does not contradict the limit.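

In this assay, among these compounds, compound 2 and compound 4 both stop at a limit of the assay, so putting hydrogen in place of benzyl on the oxygen gives no step whose size can be read. The compounds shown leave open whether any group on the shared core would give a measured value, since only one pattern appears: the limit of > 10000 nM in this assay, at which 4 of the 4 values shown sit.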